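Trifluoromethoxy Ester Analogue: Expected Cytotoxicity

This account rests on a few compounds, and the source may have more. Where it says the series, first, only, none or still open, it means among the compounds named here.

Compound 1 `CC(C)N(Cc1cccc(OCCCCCC(=O)O)c1)C(=O)c1ccc(-c2cccc(O)c2)cc1` gives > 26000 nM in an ADME assay on HepG2 cells (Homo sapiens) for cytotoxicity, read by CellTiter-Glo and resazurin assay, with a stated time of 72 h (on this read-out lower numbers stand for an effect already at smaller amounts and higher numbers for an effect only at larger amounts of compound), a limit of the assay.
Compound 2 `CC(C)N(Cc1cccc(OCCCCCC(=O)O)c1)C(=O)c1ccc(-c2cccc(OC(F)(F)F)c2)cc1` gives > 26000 nM in this assay, a limit of the assay.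
Compound 3 `CCOC(=O)CCCCCOc1cccc(CN(C(=O)c2ccc(-c3cccc(O)c3)cc2)C(C)C)c1` gives > 26000 nM in this assay, a limit of the assay.

Compound 2 differs from compound 1 by trifluoromethyl in place of hydrogen on an oxygen on an aromatic ring. The resulting step in this assay is a step that the two limits leave unreadable from compound 1 to compound 2, since both values rest at the limit of > 26000 nM in this assay, at which 3 of the 3 values shown sit. Compound 3 differs from compound 1 in its core by ethyl in place of hydrogen on an oxygen next to a carbonyl group; its step from compound 1, a step that the two limits leave unreadable from compound 1 to compound 3, is likewise not readable for the same reason, (the limit of > 26000 nM in this assay, at which 3 of the 3 values shown sit).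

Compound 4 `CCOC(=O)CCCCCOc1cccc(CN(C(=O)c2ccc(-c3cccc(OC(F)(F)F)c3)cc2)C(C)C)c1` has not been measured. It differs from compound 3 by trifluoromethyl in place of hydrogen on an oxygen on an aromatic ring, the same change as that from compound 1 to compound 2, made at the same place. Because compound 3 sits at the limit of > 26000 nM in this assay, at which 3 of the 3 values shown sit, and the earlier instance of this change gave a step that the two limits leave unreadable from compound 1 to compound 2, the step from compound 3 to compound 4 in this assay is expected to be a step that the limit leaves unreadable from compound 3 to compound 4. Compound 4 is accordingly estimated at 40000 nM in this assay, most likely again reported only as a limit.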

Compound 4, half-maximal effective concentration: > 26000 nM
Compound 4: only a limit was reported; the forecaster's own chance of this, stated with the estimate: 85%; the middle value lies beyond the limit too.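

Neither step into compound 4, from compound 3 or from compound 2, can be read in this assay, because both ends of each step rest on a limit: the limit of > 26000 nM in this assay, at which 4 of the 4 values shown sit.

The compounds shown leave open at what concentration any of them would show an effect in this assay, and whether the trifluoromethyl or ethyl change shifts it.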